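Removing One Chloro Group from a Thromboxane Receptor Antagonist

The source may report more compounds than this note shows. Statements on the series, on what has been measured and on what is new or still open speak of the compounds shown alone.

For the measured compounds named here, the three compounds measured so far all pair an aryl sulfonamide with an acid-bearing side chain on a five-membered core. Compound 1 `O=C(O)CC/C=C\C[C@H]1[C@H](F)CC[C@@H]1NS(=O)(=O)c1ccc(Cl)c(Cl)c1` carries a 3,4-dichlorophenyl on the sulfonamide; in a functional assay on a cell-free system (plasma) for inhibition of thromboxane A2 receptor (Homo sapiens), read by turbidimetry (on this read-out higher numbers stand for weaker inhibition and lower numbers for stronger inhibition), compound 1 gives 1700 nM. Compound 2 `Cc1ccc(S(=O)(=O)N[C@H]2CC[C@@H](F)[C@@H]2CCCCOCC(=O)O)cc1` gives 1800 nM in this assay, and compound 3 `O=C(O)CC/C=C\CC1=CCC[C@@H]1NS(=O)(=O)c1ccc(Cl)cc1` gives 1900 nM. The number for compound 1 lies within the scatter of both of the other two, so on these measurements the three compounds cannot be told apart.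

Compound 4 `O=C(O)CC/C=C\C[C@H]1[C@H](F)CC[C@@H]1NS(=O)(=O)c1ccc(Cl)cc1` differs from compound 1 in one place: hydrogen in place of chloro on an aromatic carbon, at a position ortho to a chloro group and meta to a large group; cut one bond further out, the same difference reads 3,4-dichlorophenyl to 4-chlorophenyl. Going by the values given here, no measured pair isolates this step. Compound 3 also carries a 4-chlorophenyl, but on a different core, so the value of compound 3, 1900 nM, does not speak for the chloro alone. With all three numbers in hand lying close together, the step is expected to be a 1.4-fold higher number from compound 1 to compound 4 (0.13 log units; within the scatter), no larger than the scatter and leaning, if anywhere, toward weaker inhibition. Compound 4 is therefore estimated at 2300 nM, with a range from 1000 nM to 5500 nM.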

Compound 4, half-maximal inhibitory concentration: 210 nM
The estimate for compound 4 lay 11-fold (1.04 log units) above the measured number; the measured number lies below the stated range.
By their numbers in this assay, from the lowest: compound 4; then compounds 1, 2 and 3 (each within the scatter of the next).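

In this assay, the chloro on an aromatic carbon, ortho to a chloro group and meta to a large group, turns out to matter: hydrogen in its place gives an 8.1-fold lower number from compound 1 to compound 4 (0.91 log units; beyond the scatter), a step beyond the scatter. The earlier compounds shown here, all within the scatter of one another and with no single change isolated between them, gave no sign of this. Only one chlorine leaves and one hydrogen enters, with the core and the acid-bearing side chain of compound 1 kept. The stronger inhibition of compound 4 can be placed at this one position on the six-membered aromatic ring. Nothing available here bears on why this change has so large an effect.

The compounds shown leave open whether a bromo, a methoxy or a nitrile at this position would keep the number of compound 4 or bring it back toward that of compound 1. They also leave open whether the remaining chloro of compound 4 can give way to hydrogen, and whether the same step holds on the core of compound 3.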